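Fluoro to chloro exchange: expected inhibition of compound 4

A few compounds are considered here, and "the series" means these few. Any claim that something is new, unique, unknown or untested is made for them only; others in the source may bear on it.

Measured compounds:
Compound 1 `Clc1cccc(-c2nc3ccc(N4CCCCC4)nc3o2)c1` gives 91.7% in an assay on isolated protein for inhibition of Amine oxidase [flavin-containing] B (Homo sapiens), read by fluorescence, with a stated time of 1 h, tested at 10 uM; on this read-out lower numbers stand for less inhibition and higher numbers for more inhibition at the one concentration tested (going by the name of the read-out).
Compound 2 `c1ccc(-c2nc3ccc(N4CCCCC4)nc3s2)cc1` gives 95.5% in this assay.
Compound 3 `Fc1ccc(-c2nc3ccc(N4CCCCC4)nc3s2)cc1` gives 92.7% in this assay.

Compound 3 stands second highest of the three numbers, but both its neighbours lie within the scatter of it: compound 1 sits slightly lower and compound 2 slightly higher, so the three values cannot be ordered with confidence. All three are strongly inhibited at the one concentration tested.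

Compound 4 `Clc1ccc(-c2nc3ccc(N4CCCCC4)nc3s2)cc1` differs from compound 3 in one place: chloro in place of fluoro on an aromatic carbon.

Going by the values given here, the only measured one-place step is a number 2.8 percentage points lower from compound 2 to compound 3 (within the scatter), which adds a fluoro and stays within the scatter. Among the compounds with values here, no measured step exchanges fluoro for chloro, but compound 1, which carries a chloro on its phenyl, gives 91.7%, close to compound 2 and compound 3. Nothing in the series suggests that a halogen on the phenyl moves the read-out. The expected step is therefore a number 0.3 percentage points higher from compound 3 to compound 4 (within the scatter), nothing beyond the scatter. Compound 4 is estimated at 93%, in the range 85% to 98%.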

Compound 4, a percentage reported as inhibition, at one concentration (the size of the read-out at that concentration, not a potency): 84.2%
Compound 4: middle estimate off by 8.8 percentage points, on the high side, outside the stated range (below it).
By their numbers in this assay, from the lowest: compounds 4, 1, 3 and 2 (each within the scatter of the next, the first and the last beyond it).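

In this assay, going by these compounds alone, chloro in place of hydrogen on the phenyl, para to a large group, gives the first one-place step to pass the scatter (a number 11.3 percentage points lower from compound 2 to compound 4 (beyond the scatter)), so this position is not indifferent to every substituent. Fluoro in place of hydrogen stays within the scatter (a number 2.8 percentage points lower from compound 2 to compound 3 (within the scatter)), and so does the direct exchange of fluoro for chloro (a number 8.5 percentage points lower from compound 3 to compound 4 (within the scatter)), which means the two halogens cannot be separated from each other on these numbers. No measurement is at hand that bears on the reason for the chloro result.

Open, as far as these compounds go, is whether a methoxy, an amine or a carboxylic acid at this position would read with hydrogen or with chloro. Also open, from the compounds shown here alone, is whether the chloro step holds with the core of compound 1, and how these single-concentration readings relate to potency.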